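A few compounds are considered here, and "the series" means these few. Any claim that something is new, unique, unknown or untested is made for them only; others in the source may bear on it.

Measured compounds:
- compound 1 `Cc1nc(N)c2nc(-c3ccccc3)sc2n1`: 34 nM
- compound 2 `Nc1nc(-c2ccc(CO)cc2)nc2sc(-c3ccccc3)nc12`: 82 nM

Both were tested in an assay on CHO cells for displacement of a labelled ligand from adenosine receptor A1 (Homo sapiens), read by scintillation counting, with a stated time of 3 h; on this read-out higher numbers stand for weaker inhibition and lower numbers for stronger inhibition. Compound 2 gives 82 nM, the highest of the two numbers shown; its nearest neighbour, compound 1, gives 34 nM. Going by the values given here, the only measured step, a 2.4-fold higher number from compound 1 to compound 2 (0.38 log units; beyond the scatter), is a modest one that came from putting 4-(hydroxymethyl)phenyl in place of methyl on an aromatic carbon.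

Compound 3 `N#Cc1cccc(-c2nc(N)c3nc(-c4ccccc4)sc3n2)c1` has not yet been measured. The change that leads to it is 3-cyanophenyl in place of 4-(hydroxymethyl)phenyl on an aromatic carbon. Among the compounds with values here, no measured step swaps one aryl group for another at this position, so the step from compound 1 to compound 2 bears on it only loosely. In this assay a step no larger than the scatter is expected, in either direction. The estimate for compound 3 is 60 nM, within a range of 20 nM to 180 nM, which means an expected step of a 1.4-fold lower number from compound 2 to compound 3 (0.14 log units; within the scatter).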

Compound 3, inhibition constant: 594 nM
For compound 3 the middle estimate is 9.9-fold (1.00 log units) below the measured one; measured number above the stated range.
By their numbers in this assay, from the lowest: compound 1; then compound 2; then compound 3.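

In this assay, the choice of aryl group at this position clearly matters: exchanging 4-(hydroxymethyl)phenyl for 3-cyanophenyl gives a 7.2-fold higher number from compound 2 to compound 3 (0.86 log units; beyond the scatter), even though each group is built on one six-membered aromatic ring of carbon. Measured against the methyl group, the 3-cyanophenyl group gives a 17-fold higher number from compound 1 to compound 3 (1.24 log units; beyond the scatter), a large step, so replacing methyl with an aryl group here does not have one fixed cost. No available evidence explains this loss of binding strength.

Compound 2 and compound 3 differ both in the substituent and in where it sits on the phenyl ring, so the effects of these two changes remain unseparated. Also open, going by these compounds, is how an unsubstituted phenyl group, or a phenyl ring carrying an amine or a carboxylic acid, would behave at this position.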